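The source may report more compounds than this note shows. Statements on the series, on what has been measured and on what is new or still open speak of the compounds shown alone.

Measured in a functional assay on LOX IMVI cells (Homo sapiens) for cytotoxicity, read by MTT assay, with a stated time of 24 h; a higher number here means a weaker inhibitor, a lower number a stronger inhibitor:
- compound 1 `COc1cc(-c2nc(-c3ccccc3)[nH]c2-c2ccnc(NCCCNS(=O)(=O)c3ccc(F)cc3)n2)ccc1Cl`: 4530 nM
- compound 2 `COc1cc(-c2nc(-c3ccccc3)[nH]c2-c2ccnc(NCCCNS(=O)(=O)c3ccc(C(F)(F)F)cc3)n2)ccc1Cl`: 1780 nM

Compound 2 holds the lower of the two numbers, at 1780 nM. Compound 3 `O=S(=O)(NCCCNc1nccc(-c2[nH]c(-c3ccccc3)nc2-c2ccc(Cl)c(O)c2)n1)c1ccc(C(F)(F)F)cc1` differs from it by hydrogen in place of methyl on an oxygen on an aromatic ring, so methoxy becomes hydroxy. Among the measured compounds shown here, the one measured step, a 2.5-fold lower number from compound 1 to compound 2 (0.41 log units; beyond the scatter), is a modest change of trifluoromethyl in place of fluoro on an aromatic carbon. It lies elsewhere in the structure, so it gives only a rough scale for single changes in this series. For the measured compounds named here, no measured pair tests methoxy against hydroxy, and the direction in this assay remains open. A small step is expected, perhaps to a slightly lower number, and the estimate is a 1.2-fold lower number from compound 2 to compound 3 (0.07 log units; within the scatter). The estimated value for compound 3 is 1500 nM, with an expected range of 600 nM to 4000 nM.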

Compound 3, half-maximal inhibitory concentration: 10100 nM
For compound 3 the middle estimate is 6.7-fold (0.83 log units) below the measured one; the measured number lies above the stated range.
By their numbers in this assay, from the lowest: compound 2; then compound 1; then compound 3.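

In this assay, among the compounds shown here, this is the first measured change at the oxygen on the aromatic ring, and methoxy to hydroxy gives a 5.7-fold higher number from compound 2 to compound 3 (0.75 log units; beyond the scatter). The methyl on this oxygen therefore counts for the number in this assay, and a single change here can move the value beyond the scatter, in the opposite direction to a 2.5-fold lower number from compound 1 to compound 2 (0.41 log units; beyond the scatter), which lies elsewhere in the structure. No measurement shown here bears on the reason for this step.

Still open, on these data alone, is whether the higher number follows from the free hydroxy or from the loss of the methyl, which an ethoxy or an amine in that place would help separate. Also open, as far as these compounds go, is whether the methoxy to hydroxy step keeps its size and direction with fluoro in place of trifluoromethyl.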